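Cytotoxicity notes: isopropyl for phenyl on the ring amine

A few compounds are considered here, and "the series" means these few. Any claim that something is new, unique, unknown or untested is made for them only; others in the source may bear on it.

The series shares one core, seen in compound 1 `Cc1ccccc1-c1nn(-c2ccc(F)cc2F)cc1CNCCCCO`, compound 2 `Cc1ccccc1-c1nn(-c2ccc(F)cc2F)cc1CNCCN1CCN(C)CC1` and compound 3 `Cc1ccccc1-c1nn(-c2ccc(F)cc2F)cc1CN1CCN(c2ccccc2)CC1`. In an ADME assay on Huh-7 cells (Homo sapiens) for cytotoxicity (on this read-out lower numbers stand for higher toxicity in this test and higher numbers for lower toxicity in this test), compound 1 gives only a limit of > 20000 nM. In this assay compound 2 likewise gives a limit, > 20000 nM. Compound 3 also stands at a limit in this assay, > 20000 nM. The step that the two limits leave unreadable from compound 1 to compound 2 is thus unreadable, and the limit of > 20000 nM in this assay, at which 3 of the 3 values shown sit, marks where every value shown sits.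

Compound 4 `Cc1ccccc1-c1nn(-c2ccc(F)cc2F)cc1CN1CCN(C(C)C)CC1` has not been measured in this assay. The change from compound 3: isopropyl in place of phenyl on an amine nitrogen in a ring. Going by the values given here, no measured step touches an amine nitrogen in a ring, and the single measured step, between compound 1 and compound 2, gives no readable size. Nothing among the three values argues for a step beyond the scatter in either direction. Compound 4 is expected to sit again near the limit, estimated at 30000 nM within 15000 nM to 60000 nM. The expected step that the limit leaves unreadable from compound 3 to compound 4 amounts to no change beyond the scatter.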

Compound 4, half-maximal cytotoxic concentration: > 20000 nM
Compound 4 was reported as a limit; the forecaster's own chance of this, stated with the estimate: 80%; the middle value does not contradict the limit.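

Going by these compounds alone, no step to compound 4 from compound 1, compound 2 or compound 3 can be read, since the values shown all stand at one limit: the limit of > 20000 nM in this assay, at which 4 of the 4 values shown sit. The compounds shown leave open how far each value lies past that limit, and whether any change on the shared core gives a readable value in this assay.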